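This account rests on a few compounds, and the source may have more. Where it says the series, first, only, none or still open, it means among the compounds named here.

Three amides of the shared core carry the dodecyl or tetradecyl chain on one amide nitrogen and a heteroaryl carbonyl on the other. Compound 1 is `CCCCCCCCCCCCNC(=O)[C@@H](NC(=O)c1cccs1)[C@@H](C)O`; in a functional assay on MCF7 cells (Homo sapiens) for cytotoxicity, read by MTT assay, with a stated time of 48 h (on this read-out higher numbers stand for weaker inhibition and lower numbers for stronger inhibition), compound 1 gives 30400 nM. Compound 2 is `CCCCCCCCCCCCNC(=O)[C@@H](NC(=O)c1cc2ccccc2o1)[C@@H](C)O`; in this assay compound 2 gives 20900 nM. The change from compound 1 to compound 2 is 1-benzofuran-2-yl in place of thiophen-2-yl on a carbonyl carbon and made a 1.5-fold lower number from compound 1 to compound 2 (0.16 log units; within the scatter). Compound 3 is `CCCCCCCCCCCCCCNC(=O)[C@@H](NC(=O)c1cccs1)[C@@H](C)O`; in this assay compound 3 gives 36100 nM, and the change from compound 1 to compound 3, (ethyl in place of hydrogen on a saturated chain carbon, ten or more bonds along the chain from an amide-type nitrogen), made a 1.2-fold higher number from compound 1 to compound 3 (0.07 log units; within the scatter). All three numbers therefore sit within the usual scatter of one another, and no ordering among them is claimed.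

Compound 4, `CCCCCCCCCCCCCCNC(=O)[C@@H](NC(=O)c1cc2ccccc2o1)[C@@H](C)O`, is not yet measured in this assay. It differs from compound 3 by 1-benzofuran-2-yl in place of thiophen-2-yl on a carbonyl carbon, the same change as from compound 1 to compound 2, at a place described in the same words. The two cores differ by ethyl in place of hydrogen on a saturated chain carbon, ten or more bonds along the chain from an amide-type nitrogen, the ethyl being far out along the saturated chain. Because the earlier instance gave a 1.5-fold lower number from compound 1 to compound 2 (0.16 log units; within the scatter), and because the chain extension itself gave only a 1.2-fold higher number from compound 1 to compound 3 (0.07 log units; within the scatter), the expectation is that the step from compound 3 to compound 4 in this assay is of similar size, a 1.4-fold lower number from compound 3 to compound 4 (0.16 log units; within the scatter), with the two changes acting independently as far as these three compounds show. For compound 4 in this assay the estimate is 25000 nM, expected to fall between 12000 nM and 50000 nM.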

Compound 4, half-maximal inhibitory concentration: 23400 nM
For compound 4 the middle estimate is 1.1-fold (0.03 log units) above the measured one; the measured number falls inside the stated range.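

In this assay, 1-benzofuran-2-yl in place of thiophen-2-yl on the carbonyl carbon gives a 1.5-fold lower number from compound 3 to compound 4 (0.19 log units; within the scatter), and the change reads the same on the dodecyl and tetradecyl cores: the same change on two cores in this assay, a 1.5-fold lower number (0.16 log units; within the scatter) from compound 1 to compound 2 and a 1.5-fold lower number (0.19 log units; within the scatter) from compound 3 to compound 4, 1.1-fold (0.03 log units) apart, within the scatter of two such steps

The tetradecyl chain in place of the dodecyl chain, with 1-benzofuran-2-yl on the carbonyl carbon, gives a 1.1-fold higher number from compound 2 to compound 4 (0.05 log units; within the scatter), and this also matches the step seen with thiophen-2-yl: the same change on two cores in this assay, a 1.2-fold higher number (0.07 log units; within the scatter) from compound 1 to compound 3 and a 1.1-fold higher number (0.05 log units; within the scatter) from compound 2 to compound 4, 1.1-fold (0.03 log units) apart, within the scatter of two such steps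

Each change can therefore be carried between these two cores without a visible shift in its step, but every step lies within the scatter, so the agreement is between small steps and shows neither that either change has a real effect nor that the two would stay independent outside these four compounds.

On these data alone, a much shorter chain such as octyl or a longer one such as octadecyl remains open, and a wider gap in chain length could give a step that can be read beyond the scatter. Also open, as far as these compounds go, is whether an amine or a carboxylic acid in the chain, or a methoxy group in place of the hydroxyl, would move the number.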